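This account rests on a few compounds, and the source may have more. Where it says the series, first, only, none or still open, it means among the compounds named here.

Measured compounds:
compound 1 `CCOC(=O)/C(O)=C/C(=O)c1cn(Cc2cccc(F)c2)c2cccc(OC)c12` gives 63200 nM
compound 2 `CCOC(=O)/C(O)=C/C(=O)c1cn(Cc2cc(F)ccc2F)c2cccc(OC)c12` gives 41200 nM
compound 3 `CCOC(=O)/C(O)=C/C(=O)c1cn(Cc2cc(F)c(F)c(F)c2)c2cccc(OC)c12` gives 33400 nM

In an ADME assay on MT4 cells (Homo sapiens) for cytotoxicity, read by MTT assay (on this read-out lower numbers stand for higher toxicity in this test and higher numbers for lower toxicity in this test), compound 3 has the lowest of the three numbers, yet its steps to the others, a 1.2-fold lower number from compound 2 to compound 3 (0.09 log units; within the scatter) and a 1.9-fold lower number from compound 1 to compound 3 (0.28 log units; within the scatter), are both within the scatter, so the three compounds cannot be told apart.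

Compound 4 `CCOC(=O)/C(O)=C/C(=O)c1cn(Cc2ccccc2F)c2cccc(OC)c12` differs from compound 3 at the benzyl group: 2-fluorophenyl in place of 3,4,5-trifluorophenyl on a saturated chain carbon bound to an aromatic nitrogen. For the measured compounds named here, the steps that bear on this change are those among the fluorinated benzyl variants, a 1.5-fold lower number from compound 1 to compound 2 (0.19 log units; within the scatter), a 1.9-fold lower number from compound 1 to compound 3 (0.28 log units; within the scatter) and a 1.2-fold lower number from compound 2 to compound 3 (0.09 log units; within the scatter), each within the scatter. A step of no size beyond the scatter is therefore expected in this assay for compound 4, a 1.5-fold higher number from compound 3 to compound 4 (0.18 log units; within the scatter), perhaps drifting back toward the numbers of compound 1. Compound 4 is estimated at 50000 nM, between 25000 nM and 100000 nM.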

Compound 4, half-maximal cytotoxic concentration: 63300 nM
Compound 4: middle estimate off by 1.3-fold (0.10 log units), on the low side; the measured number falls inside the stated range.
By their numbers in this assay, from the lowest: compounds 3, 2, 1 and 4 (each within the scatter of the next).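

In this assay, the 2-fluorophenyl group of compound 4 cannot be told apart from the other fluorinated groups: a 1.9-fold higher number from compound 3 to compound 4 (0.28 log units; within the scatter), a 1.5-fold higher number from compound 2 to compound 4 (0.19 log units; within the scatter) and a 1.0-fold higher number from compound 1 to compound 4 (0.00 log units; within the scatter). The series now covers a fluoro group at a new place on the phenyl group, and across all four compounds neither the number nor the placing of fluoro groups gives a step beyond the scatter. Nothing available explains this flat result.

As far as these compounds go, it remains open whether a group other than fluoro on this phenyl group, such as methoxy or an amine, would give a step beyond the scatter. From the compounds shown here alone, it also remains open whether a carboxylic acid in place of the ethyl ester would do so.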